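Swapping the Azole on a Thioether Core

The source may hold more compounds than are shown below. What is called first, only, known or untested is meant among the compounds shown, and "the series" means these compounds.

Measured compounds:
compound 1, `Cc1noc(C)c1-c1cnc(N)c(Oc2ccc(C(=O)Nc3ccc(Cl)cc3)cc2)n1`, 14400 nM
compound 2, `Cn1cc(-c2cnc(N)c(Oc3ccc(C(=O)Nc4ccc(Cl)cc4)cc3)n2)cn1`, 11900 nM
compound 3, `Cc1noc(C)c1-c1cnc(N)c(Sc2ccc(C(=O)Nc3ccc(Cl)cc3)cc2)n1`, 45200 nM

Of the compounds shown here, three have been tested in a functional assay on HepG2 cells (Homo sapiens) for inhibition, read by MTT assay, with a stated time of 72 h; a lower number here means a stronger inhibitor, a higher number a weaker inhibitor. Compound 1 gives 14400 nM, and compound 2 gives 11900 nM. The two differ only by 1-methyl-1H-pyrazol-4-yl in place of 3,5-dimethyl-1,2-oxazol-4-yl on an aromatic carbon, and this change gave a 1.2-fold lower number from compound 1 to compound 2 (0.08 log units; within the scatter). Compound 3 gives 45200 nM, the highest number of the three; the difference between its core and the core of compound 1 is not broken down here.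

Compound 4, `Cn1cc(-c2cnc(N)c(Sc3ccc(C(=O)Nc4ccc(Cl)cc4)cc3)n2)cn1`, has not yet been measured. It differs from compound 3 by 1-methyl-1H-pyrazol-4-yl in place of 3,5-dimethyl-1,2-oxazol-4-yl on an aromatic carbon, the same change that takes compound 1 to compound 2, made at the same place. Because the earlier step was a 1.2-fold lower number from compound 1 to compound 2 (0.08 log units; within the scatter), compound 4 is expected to land close to compound 3 in this assay, with a step estimated at a 1.2-fold lower number from compound 3 to compound 4 (0.08 log units; within the scatter). The number estimated for compound 4 is 38000 nM, expected to fall between 15000 nM and 95000 nM.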

Compound 4, half-maximal inhibitory concentration: > 100000 nM
Compound 4: no number, only a limit; the forecaster's own chance of this, stated with the estimate: 15%; middle value at least 2.6-fold (0.42 log units) away from the limit.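

In this assay compound 4 gives > 100000 nM, a limit of the assay and not a number: the limit of > 100000 nM in this assay, at which 1 of the 4 values shown sits. On the core of compound 3, putting 1-methyl-1H-pyrazol-4-yl in place of 3,5-dimethyl-1,2-oxazol-4-yl gave an at least 2.2-fold higher number from compound 3 to compound 4 (0.34 log units; beyond the scatter), so a step within the scatter on one core did not carry over as such a step to the other. Going by these compounds, this does not show that the change truly acts differently on the two cores, since the full size of the new step remains unknown: the same change on two cores in this assay, a 1.2-fold lower number (0.08 log units; within the scatter) from compound 1 to compound 2 and an at least 2.2-fold higher number (0.34 log units; beyond the scatter) from compound 3 to compound 4; the limit leaves it open whether they differ.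

With only one pair on each core, the compounds shown leave open how this change would behave on any further core. They also leave open whether a carboxylic acid or an amine, set on the same aromatic carbon in place of either five-membered ring, would give similar numbers on both cores.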